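Trifluoromethylphenyl in place of dichlorophenyl on a trimethoxyphenyl core

The source may hold more compounds than are shown below. What is called first, only, known or untested is meant among the compounds shown, and "the series" means these compounds.

Compound 1, `COc1cc(C2=NN(C(C)=O)C(c3cccc(F)c3)O2)cc(OC)c1OC`, gives 14.7%.
Compound 2, `COc1cc(C2=NN(C(C)=O)C(c3ccccc3C(F)(F)F)O2)cc(OC)c1OC`, gives 31.8%.
Compound 3, `COc1cc(C2=NN(C(C)=O)C(c3cc(Cl)cc(Cl)c3)O2)cc(OC)c1OC`, gives 0%.

In a functional assay on BGC-823 cells (Homo sapiens) for antiproliferative activity, read by MTT assay, tested at 1 uM (a lower number here means a weaker effect, a higher number a stronger effect of the compound at the concentration tested), compound 3 stands lowest of the three: a number 14.7 percentage points lower from compound 1 to compound 3 (beyond the scatter), and a number 31.8 percentage points lower from compound 2 to compound 3 (beyond the scatter). Compound 4, `COc1cc(C2=NN(C(C)=O)C(c3ccc(C(F)(F)F)cc3)O2)cc(OC)c1OC`, is not yet measured. It differs from compound 3 by 4-(trifluoromethyl)phenyl in place of 3,5-dichlorophenyl on a saturated ring carbon. For the measured compounds named here, both measured steps that end at compound 3 replace another substituted phenyl with the 3,5-dichlorophenyl group and both fall, the one from the trifluoromethyl-bearing compound 2 being large. Undoing that kind of exchange, a rise beyond the scatter is expected for compound 4. Compound 4 is estimated at 22%, with a range from 5% to 40%. The expected step is then a number 22 percentage points higher from compound 3 to compound 4 (beyond the scatter), of modest to large size.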

Compound 4, a percentage reported as inhibition, at one concentration (the size of the read-out at that concentration, not a potency): 4.2%
Compound 4: the middle estimate sits 17.8 percentage points above what was measured; the whole stated range lies above it.
By their numbers in this assay, from the lowest: compounds 3 and 4 (each within the scatter of the next); then compound 1; then compound 2.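

The trifluoromethyl group alone does not carry the higher number of compound 2: in this assay, 4-(trifluoromethyl)phenyl in place of 2-(trifluoromethyl)phenyl gives a number 27.6 percentage points lower from compound 2 to compound 4 (beyond the scatter) at this saturated ring carbon. Replacing 3,5-dichlorophenyl with 4-(trifluoromethyl)phenyl gives a number 4.2 percentage points higher from compound 3 to compound 4 (within the scatter) and so does not separate these two groups. Against 3-fluorophenyl, the same group gives a number 10.5 percentage points lower from compound 1 to compound 4 (beyond the scatter) in this series.

From the compounds shown here alone, whether an amine or a carboxylic acid on this phenyl would change the read-out remains open. Nothing shown here explains these differences.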